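Configuration at a Chain Carbon and Tolerated Concentration

The source may report more compounds than this note shows. Statements on the series, on what has been measured and on what is new or still open speak of the compounds shown alone.

Measured so far:
compound 1, `Nc1nc2c(ncn2/C=C2/C[C@H]2[C@@H](O)CO)c(=O)[nH]1`: 299000 nM
compound 2, `Nc1ncnc2c1ncn2/C=C1\C[C@H]1[C@@H](O)CO`: 264000 nM

In an ADME assay on HFF cells (Homo sapiens) for cytotoxicity, read by neutral red uptake (a higher number here means that more compound is tolerated, a lower number that less compound is tolerated), compound 1 gives 299000 nM, numerically the top of the two figures, although compound 2 at 264000 nM lies within the scatter of it, so the two are not told apart. Compound 3, `Nc1nc2c(ncn2/C=C2/C[C@H]2[C@H](O)CO)c(=O)[nH]1`, awaits measurement in this assay. Compared with compound 1, (the two compounds have the same atoms and bonds and differ only in configuration as drawn: 1 of 3 stereo elements differ; a stereocentre at a saturated chain carbon is drawn R in compound 1 and S in compound 3). Among the compounds with values here, no measured pair shows what such a change in configuration does in this assay, so the expected step of a 1.1-fold lower number from compound 1 to compound 3 (0.03 log units; within the scatter) is taken as none beyond the scatter. Compound 3 is accordingly estimated at 280000 nM, within a range from 140000 nM to 560000 nM.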

Compound 3, half-maximal cytotoxic concentration: > 300000 nM
Compound 3: no number, only a limit; the forecaster's own chance of this, stated with the estimate: 25%; middle value at least 1.0-fold (0.02 log units) from the limit.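

In this assay compound 3 gives > 300000 nM, which is a limit of the assay and not a number. Within the data shown here, this pair isolates the configuration at a saturated chain carbon for the first time, and the change from R to S gives a number no lower from compound 1 to compound 3 (the limit leaves the size open). The comparison therefore shows no loss of tolerated concentration with this change, and it can be tied to configuration alone: the fact that compounds 1 and 3 differ only in the configuration as drawn

On these data alone, how far the true figure for compound 3 lies past the limit stays open. The compounds shown also leave open what a carboxylic acid or a longer chain would do in this assay.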